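A few compounds are considered here, and "the series" means these few. Any claim that something is new, unique, unknown or untested is made for them only; others in the source may bear on it.

Measured in a functional assay for inhibition, with Sus scrofa as the target; on this read-out higher numbers stand for weaker inhibition and lower numbers for stronger inhibition:
compound 1 `CC1(C)Oc2ccc(C#N)cc2[C@@H](n2ccccc2=O)[C@]1(C)O`: > 100000 nM
compound 2 `CC1(C)Oc2ccc(C#N)cc2[C@@H](Oc2ccc(=O)[nH]n2)[C@@]1(O)COC(=O)c1ccccc1`: > 100000 nM

Compound 1 gives > 100000 nM as a limit of the read-out and not as a number, so it stands without a value of its own. Compound 2 gives > 100000 nM as a limit too. Among the measured compounds shown here, the record so far is therefore the limit of > 100000 nM in this assay, at which 2 of the 2 values shown sit, and it offers no measured step between compounds.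

The next compound, compound 3 (`CC1(C)Oc2ccc(C#N)cc2[C@@H](n2nc(N)ccc2=O)[C@]1(C)O`), keeps the core of compound 1 and alters one group on a saturated ring carbon: a group of 8 heavy atoms (4 carbon, 3 nitrogen, 1 oxygen; one six-membered aromatic ring with 2 hetero atoms) in place of a group of 7 heavy atoms (5 carbon, 1 nitrogen, 1 oxygen; one six-membered aromatic ring with 1 hetero atom), on a saturated ring carbon is the whole difference. For the measured compounds named here, with no measured step to draw on, the data give no firm size for this change in this assay and only a modest move towards stronger inhibition is expected, with another limit quite possible. The expected step is an at least 1.6-fold lower number from compound 1 to compound 3 (0.22 log units; that floor lies within the scatter) on this estimate. For compound 3 the estimated value is 60000 nM with an expected range of 10000 nM to 200000 nM in this read-out.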

Compound 3, half-maximal inhibitory concentration: 40000 nM
Estimate against measurement, compound 3: 1.5-fold (0.18 log units) above, and the stated range covers the measured number.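

In this assay, putting the group with a six-membered aromatic ring with 2 hetero atoms in place of the group with a six-membered aromatic ring with 1 hetero atom, on the saturated ring carbon next to the ring atom that bears a hydroxy group, gives an at least 2.5-fold lower number from compound 1 to compound 3 (0.39 log units; beyond the scatter). This shows that the group on this carbon can move the read-out off its limit and onto a measured number, with the shared core otherwise unchanged; the step is only a floor, and its full size cannot be read. Compound 1 and compound 2 remain at a limit of the read-out and not at a number: the limit of > 100000 nM in this assay, at which 2 of the 3 values shown sit.

The compounds shown do not separate the share of the extra ring nitrogen from that of the hydrogen-bond donor that enters with the new group, since both arrive in the single change from compound 1 to compound 3. They also leave open whether a carboxylic acid or a longer chain in the entering group would shift the read-out further in either direction.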